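The source may report more compounds than this note shows. Statements on the series, on what has been measured and on what is new or still open speak of the compounds shown alone.

Among the measured compounds shown here, compound 2 `O=[N+]([O-])c1ccc(CN2CCC(n3cc(CC(OCc4cc(-c5ccccc5F)no4)c4ccc(Br)cc4)nn3)CC2)cc1` gives 6000 nM in a functional assay on PC-3 cells (Homo sapiens) for cytotoxicity, with a stated time of 48 h (a lower number here means a stronger inhibitor, a higher number a weaker inhibitor), and is the only compound with a number in that assay. Compound 1 `O=[N+]([O-])c1ccc(CN2CCC(n3cc(CC(OCc4cc(-c5ccc(Br)cc5)no4)c4ccc(Br)cc4)nn3)CC2)cc1` gives only a limit, > 25000 nM, in this assay. For the measured compounds named here, the one measured step, an at least 4.1-fold lower number from compound 1 to compound 2 (0.61 log units; beyond the scatter), rests on that limit of > 25000 nM in this assay, at which 1 of the 2 values shown sits, and so carries only a lower bound. Compound 3 `COc1ccccc1-c1cc(COC(Cc2cn(C3CCN(Cc4ccc([N+](=O)[O-])cc4)CC3)nn2)c2ccc(Br)cc2)on1` carries methoxy in place of fluoro on an aromatic carbon. Going by the values given here, no measured step alters this group, so no direction can be read from the data. The expected step is no change at the digits printed from compound 2 to compound 3 (within the scatter), inside the scatter. Compound 3 is thus estimated at 6000 nM, with a range from 2500 nM to 15000 nM.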

Compound 3, half-maximal inhibitory concentration: > 25000 nM
Compound 3: only a limit was reported; the forecaster's own chance of this, stated with the estimate: 20%; middle value at least 4.1-fold (0.61 log units) from the limit.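

In this assay, the earlier step changed both the halogen and its place on the phenyl ring, whereas this one keeps the place and swaps only fluoro for methoxy, giving an at least 4.1-fold higher number from compound 2 to compound 3 (0.61 log units; beyond the scatter). Among the compounds shown here, that size is only a lower bound, and compound 2 remains the only compound with a number: the limit of > 25000 nM in this assay, at which 2 of the 3 values shown sit. The step between compound 1 and compound 3 cannot be read, as both values are limits.

Going by these compounds, whether chloro, hydroxyl or an amine in place of fluoro on this carbon would give a number stays open. So does how far compound 1 and compound 3 lie from their limits.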